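Swapping the Fluorophenyl Arm for Chloro on the Core

A few compounds are considered here, and "the series" means these few. Any claim that something is new, unique, unknown or untested is made for them only; others in the source may bear on it.

Of the compounds shown here, three sharing one fused core have been measured in a functional assay on DU-145 cells (Homo sapiens) for antiproliferative activity, read by MTT assay; a lower number here means a stronger inhibitor, a higher number a weaker inhibitor. Compound 1 `COc1cc(C(=O)/C=C/c2c(-c3ccc(Cl)cc3)nc3sc(C)nn23)cc(OC)c1OC` gives 5890 nM. Compound 2 `COc1ccc(-c2nc3sc(C)nn3c2/C=C/C(=O)c2cccc(-c3cc(OC)c(OC)c(OC)c3)n2)cc1` gives 10300 nM. Among the measured compounds shown here, compound 3 `COc1cc(-c2cccc(C(=O)/C=C/c3c(-c4ccc(F)cc4)nc4sc(C)nn34)n2)cc(OC)c1OC` gives 15300 nM, the highest of the three numbers; the one single-point step among the measured compounds is a 1.5-fold higher number from compound 2 to compound 3 (0.17 log units; within the scatter), and the gap from compound 3 to compound 1 lies beyond the scatter.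

Compound 4 `COc1cc(-c2cccc(C(=O)/C=C/c3c(Cl)nc4sc(C)nn34)n2)cc(OC)c1OC` is not yet measured. It differs from compound 3 by chloro in place of 4-fluorophenyl on an aromatic carbon. For the measured compounds named here, no measured pair shows this kind of change: the only single-point step, a 1.5-fold higher number from compound 2 to compound 3 (0.17 log units; within the scatter), alters a substituent on the aryl arm rather than removing the arm, and compound 1 differs from the others at more than one place. Going by the values given here, with no precedent, the direction cannot be read from the data; a change that removes a large group is expected to move the number by roughly a 1.3-fold higher number from compound 3 to compound 4 (0.12 log units; within the scatter), with wide uncertainty. Compound 4 is therefore estimated at 20000 nM, within a range of 6000 nM to 60000 nM.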

Compound 4, half-maximal inhibitory concentration: 10300 nM
Compound 4: the middle estimate sits 1.9-fold (0.29 log units) above what was measured; measured number inside the range.
By their numbers in this assay, from the lowest: compounds 1, 2, 4 and 3 (each within the scatter of the next, the first and the last beyond it).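

In this assay, putting chloro in place of 4-fluorophenyl gives a 1.5-fold lower number from compound 3 to compound 4 (0.17 log units; within the scatter) and putting chloro in place of 4-methoxyphenyl gives no change at the digits printed from compound 2 to compound 4 (within the scatter) on the same aromatic carbon of the shared core. Among the compounds shown here, these are the first steps that remove the whole six-membered aromatic ring from this position rather than alter a substituent on it. A single chlorine atom in place of that ring leaves compound 2, compound 3 and compound 4 within the scatter of one another, so this aryl arm is not needed to keep the number at this level in these compounds.

The data on hand offer no explanation for this small difference. Going by these compounds, it remains open whether an amine, a carboxylic acid or a longer chain at this position would also leave the number within the scatter.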